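The compounds below may be only part of what the source reports. "The series", "measured", "known", "first", "only" and "open" are said of these compounds alone.

Working notes on the series. Of the compounds shown here, three have been measured in a functional assay on cells for antagonist activity at Glucagon receptor (Homo sapiens), read by cAMP accumulation, in the presence of a further agent that is not named here; a higher number here means a weaker inhibitor, a lower number a stronger inhibitor. Compound 1 `CCCC(Nc1ccc(-n2cc(C(F)(F)F)cn2)nc1)c1ccc(C(=O)NCCC(=O)O)cc1` gives 1300 nM in this assay. Compound 2 `CCCC(Nc1cc(C)c(-n2cc(C(F)(F)F)cn2)c(C)c1)c1ccc(C(=O)NCCC(=O)O)cc1` gives 1400 nM in this assay, and the two values sit within the usual scatter of each other. Compound 3 `CCC(Oc1ccc(-n2cc(C(F)(F)F)cn2)cc1)c1ccc(C(=O)NCCC(=O)O)cc1` returns > 22000 nM in this assay, which is a limit of the assay and not a number. Within the data shown here, compound 3 is thus the one value of the three that stands at the assay limit, as the evidence records it: the limit of > 22000 nM in this assay, at which 1 of the 3 values shown sits. Compounds 1 and 2 differ from compound 3 in more than one place, so the gap between them and compound 3 cannot be assigned to a single change.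

The next compound, compound 4 `CCCC(Oc1ccc(-n2cc(C(F)(F)F)cn2)cc1)c1ccc(C(=O)NCCC(=O)O)cc1`, is not yet measured in this assay. It differs from compound 3 only in one place: methyl in place of hydrogen on a saturated chain carbon, three bonds along the chain from an aromatic carbon and an oxygen on an aromatic ring; cut one bond further out the same change reads ethyl to propyl. Among the measured compounds shown here, no single-change step between measured compounds is available to gauge this change. The expectation for the step from compound 3 to compound 4 in this assay is a modest gain in potency, an at least 1.8-fold lower number from compound 3 to compound 4 (0.26 log units; that floor lies within the scatter), though with real uncertainty. Compound 4 is therefore estimated at 12000 nM in this assay, with a likely range from 3000 nM to 40000 nM.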

Compound 4, antagonist equilibrium constant: 5100 nM
Beside the measured number, compound 4's estimate is 2.4-fold (0.37 log units) above it; low and high end bracket the measured number.
By their numbers in this assay, from the lowest: compounds 1 and 2 (each within the scatter of the next); then compound 4. At a limit, above all of these: compound 3.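

In this assay, the series now has its first single-place reading at this chain carbon: methyl in place of hydrogen, three bonds along the chain from an aromatic carbon and an oxygen on an aromatic ring, comes with an at least 4.3-fold lower number from compound 3 to compound 4 (0.63 log units; beyond the scatter). Among these compounds, that step is a bound and not a full size, since one of its ends is a limit of the assay: the limit of > 22000 nM in this assay, at which 1 of the 4 values shown sits. The ethyl to propyl change is therefore the first single change printed beyond the scatter, and the real gain may be larger than this bound.

Going by these compounds, whether the trend continues with a longer chain such as butyl, or holds with a branched group such as isopropyl on this carbon, stays open. On these data alone, compound 1 and compound 2 differ from compound 4 in more than one place, so it also stays open what an amine link in place of the oxygen contributes on its own, and whether the ethyl to propyl change would have the same effect with that link.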